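A few compounds are considered here, and "the series" means these few. Any claim that something is new, unique, unknown or untested is made for them only; others in the source may bear on it.

Within the data shown here, in a functional assay on HeLa cells (Homo sapiens) for cytotoxicity, read by WST assay, with a stated time of 48 h (a lower number here means a stronger inhibitor, a higher number a weaker inhibitor), two compounds sharing one core have numbers so far. Compound 1 `O[C@@H](c1ccccc1)[C@H]1CO[C@H](c2ccccc2)[C@@H](C/C=C/C2CCCCC2)C1` gives 6440 nM, and compound 2 `O[C@@H](c1ccccc1)[C@H]1CO[C@H](c2ccccc2)[C@@H](C/C=C/c2ccc(F)cc2)C1` gives 8340 nM, so compound 2 stands within the scatter of compound 1 and the two cannot be told apart. Compound 3 `O[C@@H](c1ccccc1)[C@H]1CO[C@H](c2ccccc2)[C@@H](C/C=C/c2ccccc2F)C1` keeps the same atoms as compound 2, with the fluorine joined differently: 2-fluorophenyl in place of 4-fluorophenyl on a double-bonded chain carbon bound to a double-bonded chain carbon. Among the measured compounds shown here, the only measured step that bears on this change is a 1.3-fold higher number from compound 1 to compound 2 (0.11 log units; within the scatter), which brought in 4-fluorophenyl in place of cyclohexyl at the same place on the chain. For the measured compounds named here, no measured pair tests where the fluorine sits on the ring, so no step beyond the scatter is expected in this assay. The estimate therefore means a 1.1-fold lower number from compound 2 to compound 3 (0.05 log units; within the scatter), an expected change that stays within the scatter. For compound 3 the expected value is 7500 nM, with an estimated range of 3500 nM to 16000 nM.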

Compound 3, half-maximal inhibitory concentration: 9730 nM
Compound 3: middle estimate off by 1.3-fold (0.11 log units), on the low side; low and high end bracket the measured number.
By their numbers in this assay, from the lowest: compounds 1, 2 and 3 (each within the scatter of the next).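

In this assay, among these compounds, moving the fluorine on the ring gives a 1.2-fold higher number from compound 2 to compound 3 (0.07 log units; within the scatter) and so shows that 2-fluorophenyl and 4-fluorophenyl cannot be told apart at this place on the chain, a change the earlier compounds did not test. Setting 2-fluorophenyl against cyclohexyl gives a 1.5-fold higher number from compound 1 to compound 3 (0.18 log units; within the scatter) and adds a second aromatic group whose replacement of cyclohexyl stays inside the scatter, so all three groups on this double-bonded chain carbon remain indistinguishable here. Nothing available explains why these groups read alike. The compounds shown leave open whether an amine, a carboxylic acid or a longer chain at this place would move the number beyond the scatter. They also leave open whether any change elsewhere on the shared core would do so.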